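A few compounds are considered here, and "the series" means these few. Any claim that something is new, unique, unknown or untested is made for them only; others in the source may bear on it.

Measured so far:
- compound 1, `Cn1c(=O)c2c(nc(SCCc3ccc(F)cc3)n2C)n(C)c1=O`, in an assay on microsomes for inhibition of Amine oxidase [flavin-containing] B (Homo sapiens), read by fluorescence and spectrophotometry, with a stated time of 20 min (a higher number here means a weaker inhibitor, a lower number a stronger inhibitor), gives 71 nM
- compound 2, `COc1cccc(CCSc2nc3c(c(=O)n(C)c(=O)n3C)n2C)c1`, in this assay gives 125 nM
- compound 3, `Cn1c(=O)c2c(nc([S+]([O-])CCc3ccc(Cl)cc3)n2C)n(C)c1=O`, in this assay gives 781 nM

Compound 3 stands at the highest number of the three in this assay; its gap to compound 2 and its gap to compound 1 are both beyond the scatter, so it is the weakest inhibitor shown. Among the measured compounds shown here, compound 1 and compound 2 lie within the scatter of each other, the only measured single-point step being a 1.8-fold higher number from compound 1 to compound 2 (0.25 log units; within the scatter).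

Compound 4, `Cn1c(=O)c2c(nc([S+]([O-])CCc3ccc(Br)cc3)n2C)n(C)c1=O`, is not yet measured. It differs from compound 3 in one place: bromo in place of chloro on an aromatic carbon. For the measured compounds named here, no measured pair shows a chloro-to-bromo exchange, and the one step that is measured, from compound 1 to compound 2, alters the ring substituent in a different way and stays within the scatter. Going by the values given here, that step is the only guide here, and it points to a small effect of swapping one ring substituent for another in this assay. The expected step from compound 3 to compound 4 is therefore a 1.1-fold lower number from compound 3 to compound 4 (0.05 log units; within the scatter), not beyond the scatter in either direction. Compound 4 is estimated at 700 nM in this assay, with a range from 300 nM to 1600 nM.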

Compound 4, half-maximal inhibitory concentration: 471 nM
Estimate against measurement, compound 4: 1.5-fold (0.17 log units) above; the measured number falls inside the stated range.
By their numbers in this assay, from the lowest: compounds 1 and 2 (each within the scatter of the next); then compounds 4 and 3 (each within the scatter of the next).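

Notes on the halogen position: in this assay, bromo in place of chloro on an aromatic carbon, para to a large group, gives a 1.7-fold lower number from compound 3 to compound 4 (0.22 log units; within the scatter), the first measured step in which one halogen replaces another at this ring carbon. Compound 3 and compound 4 therefore cannot be told apart in this assay, and within this pair the site accepts either chloro or bromo, a single heavy atom in each case, with no change in hydrogen-bond donors, acceptors or net charge. Nothing measured on these compounds beyond this read-out bears on the step, so the data offer no explanation for it.

No pair shown differs only at the sulfur, so the oxygen on the sulfur in compound 3 and compound 4 cannot be separated from the change of ring substituent when these two are set against compound 1 and compound 2. Also open, from the compounds shown here alone, is how the series responds to an amine or a carboxylic acid on this ring carbon, or to a longer chain between the sulfur and the ring.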